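Demethylation of a Difluorobenzyl Amide Chromone

The compounds below may be only part of what the source reports. "The series", "measured", "known", "first", "only" and "open" are said of these compounds alone.

Four compounds share a core that carries an unsaturated amide. Compound 1 `COc1ccc2c(=O)c(/C=C/C(=O)Nc3ccccc3)coc2c1` and compound 2 `O=C(/C=C/c1coc2cc(O)ccc2c1=O)Nc1ccccc1` bear a phenyl on the amide-type nitrogen, while compound 3 `COc1ccc2c(=O)c(/C=C/C(=O)NCc3ccc(F)cc3F)coc2c1` and the unmeasured compound 4 `O=C(/C=C/c1coc2cc(O)ccc2c1=O)NCc1ccc(F)cc1F` bear a 2,4-difluorobenzyl there.

In a functional assay (QGY7701 cells, Homo sapiens) for inhibition, read by MTT assay, with a stated time of 48 h (on this read-out higher numbers stand for weaker inhibition and lower numbers for stronger inhibition), compound 1 gives 14000 nM. In this assay compound 2 gives 17900 nM. The change between them is hydrogen in place of methyl on an oxygen on an aromatic ring and it produced a 1.3-fold higher number from compound 1 to compound 2 (0.11 log units; within the scatter).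

For compound 3 the value of > 100000 nM is a limit of this assay, not a number, as noted in the limit of > 100000 nM in this assay, at which 1 of the 3 values shown sits. The difference between the cores of compound 1 and compound 3 is 2,4-difluorobenzyl in place of phenyl on an amide-type nitrogen, and the measured step was an at least 7.1-fold higher number from compound 1 to compound 3 (0.85 log units; beyond the scatter).

Compound 4 differs from compound 3 by hydrogen in place of methyl on an oxygen on an aromatic ring. This is the same change as that from compound 1 to compound 2, made at the same place. Since that earlier step was a 1.3-fold higher number from compound 1 to compound 2 (0.11 log units; within the scatter), the step to compound 4 is expected to be small as well, with a step that the limit leaves unreadable from compound 3 to compound 4 as the estimated change. Because compound 3 already sits at the limit described in the limit of > 100000 nM in this assay, at which 1 of the 3 values shown sits, compound 4 is expected most likely to return a limit too. The estimate for compound 4 in this assay is 130000 nM. Its expected lower end is 50000 nM. Its expected upper end is 350000 nM.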

Compound 4, half-maximal inhibitory concentration: > 100000 nM
Compound 4 gave a limit, no number; the forecaster's own chance of this, stated with the estimate: 80%; the middle value lies beyond the limit too.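

In this assay compound 4 gives > 100000 nM, which is a limit and not a number. Compound 3 sits at the same limit, so no step can be read between compound 3 and compound 4: the limit of > 100000 nM in this assay, at which 2 of the 4 values shown sit.

The compounds shown leave open how far past the limit either compound lies, and whether methoxy to hydroxy matters at all when the amide-type nitrogen carries 2,4-difluorobenzyl.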